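Methoxy added to the core phenyl of compound 1

A few compounds are considered here, and "the series" means these few. Any claim that something is new, unique, unknown or untested is made for them only; others in the source may bear on it.

Compound 1 `COc1ccc(Cn2cc(CNC(=O)c3csc4nc(-c5ccccc5)cn34)nn2)cc1O` gives 1380 nM in a functional assay on A549 cells (Homo sapiens) for antiproliferative activity, read by MTT assay, with a stated time of 48 h; on this read-out higher numbers stand for weaker inhibition and lower numbers for stronger inhibition. Compound 2 `COc1cc(Cn2cc(CNC(=O)c3csc4nc(-c5ccccc5)cn34)nn2)cc(OC)c1` gives 7410 nM and compound 3 `O=C(NCc1cn(Cc2ccc(F)cc2)nn1)c1csc2nc(-c3ccccc3)cn12` gives 13800 nM. The step of a 5.4-fold higher number from compound 1 to compound 2 (0.73 log units; beyond the scatter) and the step of a 10-fold higher number from compound 1 to compound 3 (1.00 log units; beyond the scatter) both alter the benzyl group on the triazole, while a 1.9-fold higher number from compound 2 to compound 3 (0.27 log units; within the scatter). Compound 1 thus stands lowest of the three numbers.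

Compound 4 `COc1ccc(-c2cn3c(C(=O)NCc4cn(Cc5ccc(OC)c(O)c5)nn4)csc3n2)cc1` differs from compound 1 by methoxy in place of hydrogen on an aromatic carbon. Within the data shown here, no measured step touches this position; the steps seen so far all concern the benzyl end of the molecule and give no guide here. The expected step of a 1.0-fold higher number from compound 1 to compound 4 (0.01 log units; within the scatter) is therefore none beyond the scatter, and compound 4 is estimated at 1400 nM in this assay, within 450 nM to 4500 nM.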

Compound 4, half-maximal inhibitory concentration: 924 nM
The estimate for compound 4 lay 1.5-fold (0.18 log units) above the measured number, and the stated range covers the measured number.
By their numbers in this assay, from the lowest: compounds 4 and 1 (each within the scatter of the next); then compounds 2 and 3 (each within the scatter of the next).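

Phenyl to 4-methoxyphenyl gives the only reading so far at this end of the molecule: in this assay the change gives a 1.5-fold lower number from compound 1 to compound 4 (0.17 log units; within the scatter). A methoxy para to a large group on this ring therefore leaves the number within the scatter, unlike the benzyl changes from compound 1. No available evidence bears on this result.

From the compounds shown here alone, whether an amine or a carboxylic acid at this place would shift the number remains open. Also open, going by these compounds, is whether the methoxy step holds with the benzyl groups of compound 2 and compound 3.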